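The source may hold more compounds than are shown below. What is called first, only, known or untested is meant among the compounds shown, and "the series" means these compounds.

Measured in an ADME assay on HT-29 cells (Homo sapiens) for inhibition, read by MTT assay, with a stated time of 72 h; on this read-out lower numbers stand for stronger inhibition and higher numbers for weaker inhibition:
Compound 1, `C=CC(=O)Nc1cccc(Nc2nc(N/N=C/c3ccc(F)cc3F)ncc2Cl)c1`: 4760 nM
Compound 2, `C=CC(=O)Nc1cccc(Nc2nc(N/N=C(\C)c3ccc(F)cc3)ncc2Cl)c1`: 5050 nM

Within the data shown here, only two compounds have been measured, and they sit close together: the step of a 1.1-fold higher number from compound 1 to compound 2 (0.03 log units; within the scatter) is within the scatter, so compound 2 and compound 1 cannot be told apart on these numbers. Compound 3, `C=CC(=O)Nc1cccc(Nc2nc(N/N=C(\C)c3cccc(OC)c3)ncc2Cl)c1`, differs from compound 2 by 3-methoxyphenyl in place of 4-fluorophenyl on a carbon with a double bond to nitrogen. Among the measured compounds shown here, no measured step varies this group alone; the one step in hand, a 1.1-fold higher number from compound 1 to compound 2 (0.03 log units; within the scatter), exchanged a different aromatic ring on the same part of the shared core and left the number essentially unchanged. On that basis compound 3 is expected to give a number close to that of compound 2, with the step of a 1.0-fold lower number from compound 2 to compound 3 (0.00 log units; within the scatter) expected to lie within the scatter. For compound 3 the estimate is 5000 nM, expected to fall between 2000 nM and 12500 nM.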

Compound 3, half-maximal inhibitory concentration: 8990 nM
For compound 3 the middle estimate is 1.8-fold (0.25 log units) below the measured one; the measured number falls inside the stated range.
By their numbers in this assay, from the lowest: compounds 1, 2 and 3 (each within the scatter of the next).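

In this assay, among these compounds, the group on the carbon with a double bond to nitrogen is the only thing that changes here, and 3-methoxyphenyl in place of 4-fluorophenyl gives a 1.8-fold higher number from compound 2 to compound 3 (0.25 log units; within the scatter). Among the compounds shown here, this is the first step to vary that aromatic group alone, and even with a methoxy group replacing fluorine and a hydrogen-bond acceptor entering, compound 3 cannot be told apart from compound 2 on this read-out. Nothing measured here speaks to the cause of this step.

The compounds shown leave open whether a ring carrying an amine or a carboxylic acid at this place would give a number beyond the scatter from compound 2. They also leave open whether 4-methoxyphenyl would read like 3-methoxyphenyl.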